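A few compounds are considered here, and "the series" means these few. Any claim that something is new, unique, unknown or untested is made for them only; others in the source may bear on it.

Measured in a functional assay (Homo sapiens) for inhibition of Nucleic Acid, tested at 100 uM; on this read-out lower numbers stand for less inhibition and higher numbers for more inhibition at the one concentration tested (going by the name of the read-out):
compound 1 `CCCCCCNc1[nH]ccc2ncnc1-2`: 53%
compound 2 `OC[C@H]1OC(n2cnc3c(Nc4ccccc4)nccc32)[C@H](O)[C@@H]1O`: 4%
compound 3 `OC[C@H]1O[C@@H](n2cnc3c(S)nccc32)C[C@@H]1O`: 10%

Compound 2 holds the lowest of the three numbers in this assay. Compound 3 sits within the usual scatter of compound 2, so no order between them can be read; compound 1 stands beyond the scatter, well above compound 2. Compound 4 `CN(C)c1nccc2c1ncn2C1O[C@H](CO)[C@@H](O)[C@H]1O` differs from compound 2 in one place: dimethylamino in place of anilino on an aromatic carbon. Among the measured compounds shown here, no step between measured compounds covers this change, so no size can be read from the series. The expected step is a number 4 percentage points higher from compound 2 to compound 4 (within the scatter), within the scatter, because compound 2 gives 4% and compound 3 gives 10%, both low. For compound 4 the estimate in this assay is 8%, with a range from 0% to 25%.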

Compound 4, a percentage reported as inhibition, at one concentration (the size of the read-out at that concentration, not a potency): 0%
The estimate for compound 4 lay 8 percentage points above the measured number; measured number inside the range.
By their numbers in this assay, from the lowest: compounds 4, 2 and 3 (each within the scatter of the next); then compound 1.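

In this assay, among the compounds shown here, dimethylamino in place of anilino on an aromatic carbon next to the ring nitrogen gives a number 4 percentage points lower from compound 2 to compound 4 (within the scatter) and this is the first step read at this position. Removing the aromatic carbon ring and the hydrogen-bond donor of anilino therefore leaves no readable difference on the core of compound 2, with both compounds at the low end of the read-out. Nothing at hand explains this result.

As far as these compounds go, what a primary amine, a morpholine or a carboxylic acid at this position would give stays open. From the compounds shown here alone, it also remains open whether any group here can raise the number on this core.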